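The source may report more compounds than this note shows. Statements on the series, on what has been measured and on what is new or still open speak of the compounds shown alone.

Values in a physicochemical assay for solubility, read by LC-MS, using the shake flask method, measured as thermodynamic solubility, with a stated time of 24 h, at pH 6.5 (on this read-out lower numbers stand for lower solubility and higher numbers for higher solubility), for the measured compounds:
Compound 1 (`O=C(O)c1cccc(-n2cc(CO[C@H]3O[C@H](CO)[C@@H](O)[C@H](O)[C@@H]3O)nn2)c1`) gives > 3000 ug/mL as a limit
Compound 2 (`O=C(O)c1cncc(-n2cc(CO[C@H]3O[C@H](CO)[C@@H](O)[C@H](O)[C@@H]3O)nn2)c1`) gives > 3000 ug/mL as a limit
Compound 3 (`OC[C@H]1O[C@H](OCc2cn(-c3ccc(F)cc3)nn2)[C@@H](O)[C@@H](O)[C@@H]1O`) gives > 3000 ug/mL as a limit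

Compound 3 therefore has no exact number, only a limit (> 3000 ug/mL). It has no readable position relative to the others, since the whole set shares the limit of > 3000 ug/mL in this assay, at which 3 of the 3 values shown sit, in the measurements so far.

Compound 4 (`OC[C@H]1O[C@H](OCc2cn(-c3cccc(F)c3)nn2)[C@@H](O)[C@@H](O)[C@@H]1O`) has the same atoms as compound 3, joined differently, with 3-fluorophenyl in place of 4-fluorophenyl on an aromatic nitrogen.

Three measured steps change the group on that same aromatic nitrogen, namely a step that the two limits leave unreadable from compound 1 to compound 2 and a step that the two limits leave unreadable from compound 1 to compound 3 and also a step that the two limits leave unreadable from compound 2 to compound 3 so none of them gives a size to carry over. With no readable size to draw on, no direction can be expected in this assay for this change. The estimated step is a number no higher from compound 3 to compound 4 (the limit leaves the size open) and it is expected to stay within the scatter. For compound 4 the expected value is 3000 ug/mL with an estimated range from 1200 ug/mL to 6000 ug/mL and a strong chance of being only a limit.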

Compound 4, solubility: > 3000 ug/mL
Compound 4 ended at the assay's limit; the forecaster's own chance of this, stated with the estimate: 80%; the middle value sits exactly at the limit.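

No new step can be read from compound 4 to compound 1, compound 2 or compound 3, since each value in this assay is only a limit: the limit of > 3000 ug/mL in this assay, at which 4 of the 4 values shown sit. Going by these compounds, the exact values of all four compounds stay open, and with them whether 3-fluorophenyl in place of 4-fluorophenyl makes any difference in this assay.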